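A few compounds are considered here, and "the series" means these few. Any claim that something is new, unique, unknown or untested is made for them only; others in the source may bear on it.

Measured so far in a functional assay on PC-3 cells (Homo sapiens) for inhibition, with a stated time of 72 h; a lower number here means a stronger inhibitor, a higher number a weaker inhibitor:
Compound 1 `COc1ccc(NC(=O)Nc2nc(Sc3c[nH]c4ccccc34)cc(N3CCN(c4ccccn4)CC3)n2)cc1` gives 33400 nM.
Compound 2 `Cc1cc(Cl)ccc1NC(=O)Nc1nc(Nc2ccccc2)cc(Sc2c[nH]c3ccccc23)n1` gives 41900 nM.
Compound 3 `Cc1cc(Cl)ccc1NC(=O)Nc1nc(NC2CC2)cc(Sc2c[nH]c3ccccc23)n1` gives 11100 nM.

Compound 3 stands lowest of the three numbers in this assay; compound 1 lies nearest and compound 2 furthest, both gaps beyond the scatter. Among the measured compounds shown here, the only one-place step measured is a 3.8-fold lower number from compound 2 to compound 3 (0.58 log units; beyond the scatter), a modest move to a lower number when cyclopropylamino replaced phenylamino on that aromatic carbon.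

Compound 4 `Cc1cc(Cl)ccc1NC(=O)Nc1nc(Sc2c[nH]c3ccccc23)cc(N2CCN(c3ccccn3)CC2)n1` has not been measured. It differs from compound 3 in one place: 4-(pyridin-2-yl)piperazin-1-yl in place of cyclopropylamino on an aromatic carbon. For the measured compounds named here, no measured step covers this exact exchange. Two points bear on it. First, the step from compound 2 to compound 3 ran to a lower number when a larger group left that carbon for cyclopropylamino, and compound 4 reverses that direction with a still larger entering group. Second, compound 1 carries the same 4-(pyridin-2-yl)piperazin-1-yl group, though on a different urea aryl, and its number sits above that of compound 3 by a gap beyond the scatter.

A modest move back to a higher number in this assay is therefore expected, a 2.7-fold higher number from compound 3 to compound 4 (0.43 log units; beyond the scatter). Compound 4 is estimated at 30000 nM, with a range from 10000 nM to 90000 nM.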

Compound 4, half-maximal inhibitory concentration: 19800 nM
Beside the measured number, compound 4's estimate is 1.5-fold (0.18 log units) above it; the range from low to high includes it.
By their numbers in this assay, from the lowest: compounds 3, 4, 1 and 2 (each within the scatter of the next, the first and the last beyond it).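

At the aromatic carbon next to the ring nitrogen, 4-(pyridin-2-yl)piperazin-1-yl in place of cyclopropylamino gives a 1.8-fold higher number from compound 3 to compound 4 (0.25 log units; within the scatter) in this assay, so this much larger group cannot be separated from cyclopropylamino here. Size of the group alone therefore does not order the numbers at this carbon: 4-(pyridin-2-yl)piperazin-1-yl in place of anilino gives a 2.1-fold lower number from compound 2 to compound 4 (0.33 log units; beyond the scatter), and anilino goes against any trend in which the larger group gives the higher number. With 4-(pyridin-2-yl)piperazin-1-yl held in place, 4-chloro-2-methylphenyl in place of 4-methoxyphenyl on the amide-type nitrogen gives a 1.7-fold lower number from compound 1 to compound 4 (0.23 log units; within the scatter), so the two aryl groups cannot be told apart in this setting.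

No supporting data explain any of these steps. Still open, on these data alone, is whether a morpholin-4-yl or dimethylamino group at this carbon, or a carboxylic acid on the urea aryl group, could take the series clearly below compound 3 at 11100 nM in this assay.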